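The compounds below may be only part of what the source reports. "The series", "measured", "known", "first", "only" and "open" are said of these compounds alone.

Compound 1 `COc1ccccc1C(=O)Nc1nc(-c2ccccn2)cs1`: 43500 nM in an ADME assay on Vero cells (Chlorocebus sabaeus) for cytotoxicity, read by MTT assay, with a stated time of 72 h; a higher number here means that more compound is needed for the effect, a lower number that less compound is needed
Compound 2 `O=C(Nc1nc(-c2ccccn2)cs1)c1ccccc1F`: "not determined" (no result reported) in this assay

Compound 2 has no single number to stand on; in this assay compound 2 gives "not determined" (no result reported). Within the data shown here, the only measured anchor is compound 1, which gives 43500 nM in this assay. Compound 3 `O=C(Nc1nc(-c2ccccn2)cs1)c1cc(F)ccc1F` differs from compound 2 by one change: fluoro in place of hydrogen on an aromatic carbon. Among the measured compounds shown here, no step between measured compounds exists, so no size of step can be read from the data; in this assay the step from compound 2 to compound 3 is expected to stay within the usual scatter, in no clear direction. Compound 3 is expected to give about 40000 nM in this assay, within 15000 nM to 100000 nM.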

Compound 3, half-maximal effective concentration: 3300 nM
Compound 3: the middle estimate sits 12-fold (1.08 log units) above what was measured, and the stated range ends above it.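

In this assay, among these compounds, compound 2 has no single number, so no step from it to compound 3 can be read. From the compounds shown here alone, what fluoro in place of hydrogen does here stays open, and no evidence at hand bears on the result for compound 3.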